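A Quinone Ring in Place of a Dimethoxyphenyl Ring

A few compounds are considered here, and "the series" means these few. Any claim that something is new, unique, unknown or untested is made for them only; others in the source may bear on it.

Compound 1, `COc1ccc(OC)c(-c2cc(-c3ccc(C(=O)N(C)Cc4ccccc4)s3)on2)c1`, in a functional assay on A549 cells (Homo sapiens) for cytotoxicity, read by XTT assay, with a stated time of 72 h; a higher number here means a weaker inhibitor, a lower number a stronger inhibitor: > 30000 nM.
Compound 2, `COc1ccc(CN(C)C(=O)c2ccc(-c3cc(-c4cc(OC)ccc4OC)no3)s2)cc1`, in this assay: > 30000 nM.
Compound 3, `COc1ccc(OC)c(-c2cc(-c3ccc(C(=O)N4CCCC4)s3)on2)c1`, in this assay: > 30000 nM.

Each of these three values is a limit of the assay, not a number. The value of compound 2 is such a limit, and the same holds across the set: the limit of > 30000 nM in this assay, at which 3 of the 3 values shown sit. Compound 2 therefore stands where every measured compound stands, and no order among the three can be read. Three single-point changes connect them: a step that the two limits leave unreadable from compound 1 to compound 2, a step that the two limits leave unreadable from compound 1 to compound 3 and a step that the two limits leave unreadable from compound 2 to compound 3. Each is unreadable, both of its ends sitting at the limit.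

Compound 4, `COc1ccc(CN(C)C(=O)c2ccc(-c3cc(C4=CC(=O)C=CC4=O)no3)s2)cc1`, differs from compound 2 in one place: a group of 8 heavy atoms (6 carbon, 2 oxygen; one six-membered non-aromatic ring of carbon only) in place of a group of 10 heavy atoms (8 carbon, 2 oxygen; one six-membered aromatic ring of carbon only), on an aromatic carbon. Within the data shown here, none of the measured steps changes this part of the shared core, and all three are unreadable, so they give no size and no direction to expect in this assay; a reading within the scatter or a move in either direction remains open. Compound 4 is estimated at 15000 nM, within a range from 2000 nM to 80000 nM. The step this estimate implies is expected to be an at least 2.0-fold lower number from compound 2 to compound 4 (0.30 log units; that floor lies within the scatter), with a fair chance that only a limit is reported again.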

Compound 4, half-maximal inhibitory concentration: > 30000 nM
Compound 4 gave a limit, no number; the forecaster's own chance of this, stated with the estimate: 40%; at least 2.0-fold (0.30 log units) between middle value and limit.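

Compound 4, like compound 2, gives only a limit of the assay and no number, so the step between these two compounds cannot be read. The result adds no order to the set: the limit of > 30000 nM in this assay, at which 4 of the 4 values shown sit.

From the compounds shown here alone, whether the ring that enters in compound 4 changes the potency in this assay at all, or in which direction, remains open.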